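The source may hold more compounds than are shown below. What is called first, only, known or untested is meant among the compounds shown, and "the series" means these compounds.

Compound 3 `C=CC(=O)Nc1cc(Nc2nc(C)cc(-c3cn(C)c4ccccc34)n2)c(OC)cc1N(C)CCN(C)C` is the weakest-looking member of the three compounds measured in a functional assay on HepG2 cells (Homo sapiens) for antiproliferative activity, read by MTT assay, with a stated time of 72 h; on this read-out lower numbers stand for stronger inhibition and higher numbers for weaker inhibition: compound 3 gives 12600 nM, the highest of the three numbers. Its nearest neighbour on that scale is compound 1 `CC/C=C\C(=O)Nc1cc(Nc2nccc(-c3cn(C)c4ccccc34)n2)c(OC)cc1N(C)CCN(C)C`, which in this assay gives 6670 nM, a gap that lies within the scatter; the furthest is compound 2 `CC/C=C\C(=O)Nc1cc(Nc2ncc(C#N)c(-c3cn(C)c4ccccc34)n2)c(OC)cc1N(C)CCN(C)C`, which gives 1360 nM. Within the data shown here, the only single-point step among the measured compounds is a 4.9-fold lower number from compound 1 to compound 2 (0.69 log units; beyond the scatter), and it concerns a change on the core, not on the amide chain.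

Compound 4 `CCC/C=C\C(=O)Nc1cc(Nc2nc(C)cc(-c3cn(C)c4ccccc34)n2)c(OC)cc1N(C)CCN(C)C` differs from compound 3 only in the amide chain: pent-1-en-1-yl in place of vinyl on a carbonyl carbon. Among the measured compounds shown here, no measured step addresses this change directly. Compound 1 and compound 3 carry different chain lengths together with a second difference on the core, and their two numbers sit within the scatter of each other, so nothing in hand argues for a large move. Compound 4 is therefore expected to show a 1.3-fold lower number from compound 3 to compound 4 (0.10 log units; within the scatter), a step not beyond the scatter, and its estimated value is 10000 nM, with a range from 4000 nM to 25000 nM.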

Compound 4, half-maximal inhibitory concentration: 365 nM
Estimate against measurement, compound 4: 27-fold (1.44 log units) above; the whole stated range lies above it.
By their numbers in this assay, from the lowest: compound 4; then compound 2; then compounds 1 and 3 (each within the scatter of the next).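

In this assay, among these compounds, the amide chain turns out to be a place where a single change moves the number a long way: pent-1-en-1-yl in place of vinyl on a carbonyl carbon gives a 35-fold lower number from compound 3 to compound 4 (1.54 log units; beyond the scatter) and is the first measured step on this chain, the only earlier step being on the core. The entering and leaving groups match in their counts of double bonds, rings, hydrogen-bond donors and acceptors, and differ in their carbon count, 5 against 2. Nothing shown explains why the step is this large.

On these data alone, whether a longer chain such as hept-1-en-1-yl would go further, or a saturated pentyl group would do the same, stays open. So does whether pent-1-en-1-yl would give a similar step on the core of compound 2.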